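Working notes: replacing the chain substituent of compound 3

A few compounds are considered here, and "the series" means these few. Any claim that something is new, unique, unknown or untested is made for them only; others in the source may bear on it.

Values in a functional assay on RS4-11 cells (Homo sapiens) for inhibition, read by CCK-8 assay, with a stated time of 72 h (a higher number here means a weaker inhibitor, a lower number a stronger inhibitor), so far:
- compound 1 `CC1(C)CCC(CN2CCN(c3ccc(C(=O)NS(=O)(=O)c4ccc(NCC5CCOCC5)c([N+](=O)[O-])c4)c(Oc4cnc5[nH]ccc5c4)c3)CC2)=C(c2ccc(C(F)(F)F)cc2)C1` gives 6.2 nM
- compound 2 `CN(C)CCCNc1ccc(S(=O)(=O)NC(=O)c2ccc(N3CCN(CC4=C(c5ccc(C(F)(F)F)cc5)CC(C)(C)CC4)CC3)cc2Oc2cnc3[nH]ccc3c2)cc1[N+](=O)[O-]` gives 3.9 nM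
- compound 3 `CC(C)C(=O)N1CCC(CNc2ccc(S(=O)(=O)NC(=O)c3ccc(N4CCN(CC5=C(c6ccc(C(F)(F)F)cc6)CC(C)(C)CC5)CC4)cc3Oc3cnc4[nH]ccc4c3)cc2[N+](=O)[O-])CC1` gives 5.3 nM
- compound 4 `CC1(C)CCC(CN2CCN(c3ccc(C(=O)NS(=O)(=O)c4ccc(NCC5CCOC5)c([N+](=O)[O-])c4)c(Oc4cnc5[nH]ccc5c4)c3)CC2)=C(c2ccc(C(F)(F)F)cc2)C1` has not yet been measured

Compound 3, at 5.3 nM in this assay, lies within the scatter of both other compounds, so the three values cannot be ranked.

The next step places oxolan-3-yl in place of 1-(isopropylcarbonyl)piperidin-4-yl on a saturated chain carbon bound to a nitrogen on an aromatic ring.

All three measured steps changed this same substituent. The step of a 1.2-fold lower number from compound 1 to compound 3 (0.07 log units; within the scatter) removes oxan-4-yl and brings in the group that now leaves. The steps of a 1.6-fold lower number from compound 1 to compound 2 (0.20 log units; within the scatter) and a 1.4-fold higher number from compound 2 to compound 3 (0.13 log units; within the scatter) also stayed within the scatter, despite the different groups involved. On these three steps alone, the expected result in this assay is a 1.0-fold higher number from compound 3 to compound 4 (0.02 log units; within the scatter), which means no expected step beyond the scatter and no firm direction.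

For compound 4 the estimated value is 5.5 nM, with an expected range of 2.7 nM to 11 nM here.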

Compound 4, half-maximal inhibitory concentration: 24.2 nM
Beside the measured number, compound 4's estimate is 4.4-fold (0.64 log units) below it; measured number above the stated range.
By their numbers in this assay, from the lowest: compounds 2, 3 and 1 (each within the scatter of the next); then compound 4.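

In this assay, this substituent now makes a difference beyond the scatter: oxolan-3-yl gives a 4.6-fold higher number from compound 3 to compound 4 (0.66 log units; beyond the scatter), and the same comparison with the other two groups gives a 6.2-fold higher number from compound 2 to compound 4 (0.79 log units; beyond the scatter) and a 3.9-fold higher number from compound 1 to compound 4 (0.59 log units; beyond the scatter). The three earlier groups, 1-(isopropylcarbonyl)piperidin-4-yl, 2-(dimethylamino)ethyl and oxan-4-yl, could not be told apart, yet all three now stand on the same side of oxolan-3-yl, so the position does not accept every group equally. Oxan-4-yl and oxolan-3-yl both carry a ring oxygen, so that oxygen alone does not keep the number low, and no measurement shown accounts for the step.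

As far as these compounds go, it remains open whether the higher number goes with the smaller ring or with the way the ring is attached. Oxolan-2-yl and cyclopentyl on the same saturated chain carbon would help to separate these readings.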